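Series notes: tert-butyl to hydrogen on the benzyl group

A few compounds are considered here, and "the series" means these few. Any claim that something is new, unique, unknown or untested is made for them only; others in the source may bear on it.

Measured compounds:
compound 1 `CCN(CC)Cc1ccc2nc(NC(=O)N/N=C/c3cn(Cc4ccc(C(C)(C)C)cc4)c4ccccc34)sc2c1`: 2120 nM
compound 2 `CN(C)Cc1ccc2nc(NC(=O)N/N=C/c3cn(Cc4ccc(C(C)(C)C)cc4)c4ccccc34)sc2c1`: 2230 nM

In a functional assay on MDA-MB-231 cells (Homo sapiens) for cytotoxicity, read by MTT assay, with a stated time of 72 h (on this read-out higher numbers stand for weaker inhibition and lower numbers for stronger inhibition), compound 1 gives 2120 nM and compound 2 gives 2230 nM. Compound 1 and compound 2 stand together: the step of a 1.1-fold higher number from compound 1 to compound 2 (0.02 log units; within the scatter) is within the scatter, so the two cannot be told apart. That step concerns the amine on the other side of the shared core and carries no information about the benzyl group.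

Compound 3 `CCN(CC)Cc1ccc2nc(NC(=O)N/N=C/c3cn(Cc4ccccc4)c4ccccc34)sc2c1` differs from compound 1 by hydrogen in place of tert-butyl on an aromatic carbon. Going by the values given here, no measured step touches this position, and the single measured step elsewhere left the number unchanged, so there is no direct guide. In this assay the expected step for compound 3 is a 1.4-fold higher number from compound 1 to compound 3 (0.15 log units; within the scatter), small and uncertain, with a wide range to cover the lack of data. Compound 3 is estimated at 3000 nM, between 1000 nM and 9000 nM.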

Compound 3, half-maximal inhibitory concentration: 1470 nM
Beside the measured number, compound 3's estimate is 2.0-fold (0.31 log units) above it; the range from low to high includes it.
By their numbers in this assay, from the lowest: compounds 3, 1 and 2 (each within the scatter of the next).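

In this assay, hydrogen in place of tert-butyl on the benzyl group gives a 1.4-fold lower number from compound 1 to compound 3 (0.16 log units; within the scatter), so compound 1 and compound 3 cannot be told apart. Going by these compounds alone, this is the first measured reading at this position: the amine step left the benzyl group untouched, whereas this pair shows that the 4-(tert-butyl)benzyl and benzyl forms read alike, with the diethylamino side chain held constant. Nothing measured explains this result.

As far as these compounds go, whether the position stays this flat for other groups on the same aromatic carbon, such as methoxy, a carboxylic acid or a primary amine, remains open. Also open, from the compounds shown here alone, is whether the benzyl form reads the same alongside the dimethylamino side chain of compound 2.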